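The compounds below may be only part of what the source reports. "The series", "measured", "known", "first", "only" and "open" are said of these compounds alone.

Measured so far, in a functional assay on WiDr cells (Homo sapiens) for inhibition, read by sulforhodamine B assay, with a stated time of 48 h; on this read-out higher numbers stand for weaker inhibition of growth and lower numbers for stronger inhibition of growth:

Compound 1 `O=C(OCC1COCCOCCOCCOCCOCCO1)c1cccc(-c2ccc(Br)cc2)c1` gives 6200 nM.
Compound 2 `CC(C)=CC1C(C(=O)OCC2COCCOCCOCCOCCOCCO2)C1(C)C` gives 56000 nM.
Compound 3 `O=C(CCCCCCCCCCOc1ccccc1)OCC1COCCOCCOCCOCCOCCO1` gives 66000 nM.

Compound 2 stands second highest of these three numbers. Its nearest neighbour is compound 3, whose value lies within the scatter of repeated measurements, so no order between the two can be read. Compound 1 stands furthest from it, with a clearly lower number, beyond the scatter.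

Compound 4 `O=C(OCC1COCCOCCOCCOCCOCCO1)c1cccnc1` has not yet been measured. It differs from compound 2 in one place: pyridin-3-yl in place of 2,2-dimethyl-3-(2-methylprop-1-en-1-yl)cyclopropyl on a carbonyl carbon. Compound 1 carries an aromatic group on its carbonyl carbon and shows the lowest number, so a drop in the number is expected from compound 2 to compound 4, a moderate one: a 2.2-fold lower number from compound 2 to compound 4 (0.35 log units; beyond the scatter). For compound 4 the estimate is 25000 nM, between 7000 nM and 90000 nM.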

Compound 4, concentration for 50% growth inhibition: > 100000 nM
Compound 4 was reported as a limit; the forecaster's own chance of this, stated with the estimate: 20%; middle value at least 4.0-fold (0.60 log units) from the limit.
By their numbers in this assay, from the lowest: compound 1; then compounds 2 and 3 (each within the scatter of the next). At a limit, above all of these: compound 4.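

In this assay compound 4 gives > 100000 nM, which is a limit of the assay and not a number. Pyridin-3-yl in place of 2,2-dimethyl-3-(2-methylprop-1-en-1-yl)cyclopropyl on a carbonyl carbon gives an at least 1.7-fold higher number from compound 2 to compound 4 (0.25 log units; that floor lies within the scatter), so this change brings no drop in the number, though that floor alone does not establish a loss. An aromatic ring at this place is therefore not enough on its own to give a lower number.

From the compounds shown here alone, how far the true value of compound 4 lies past the limit stays open. Also open, going by these compounds, is whether a plain phenyl ring, or a pyridin-3-yl carrying an amine, would lower the number on this carbonyl carbon.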